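The source may report more compounds than this note shows. Statements on the series, on what has been measured and on what is new or still open speak of the compounds shown alone.

Working notes on the series. The shared core is seen in compound 1 `Cc1nc(Nc2cccc(Cl)c2)sc1C(=O)/C=C/c1ccccc1`. In a functional assay on BGC-823 cells (Homo sapiens) for cytotoxicity, read by MTT assay (a lower number here means a stronger inhibitor, a higher number a weaker inhibitor), compound 1 gives > 25000 nM, which is a limit of the assay and not a number. Compound 2 `Cc1nc(Nc2cccc(Cl)c2)sc1C(=O)/C=C/c1ccc(Cl)cc1` carries a chloro in place of hydrogen on an aromatic carbon; in this assay compound 2 gives > 25000 nM, again a limit. Compound 3 `COc1cc(/C=C/C(=O)c2sc(Nc3ccc(Cl)c(Cl)c3)nc2C)cc(OC)c1OC` in this assay gives > 25000 nM, once more a limit. The step that the two limits leave unreadable from compound 1 to compound 2 is therefore unreadable in size. All values shown sit together at the limit of > 25000 nM in this assay, at which 3 of the 3 values shown sit, so compound 1 stands nowhere more precise than this limit.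

Compound 4 `Cc1ccc(Nc2nc(C)c(C(=O)/C=C/c3ccccc3)s2)cc1` differs from compound 1 by 4-methylphenyl in place of 3-chlorophenyl on a nitrogen on an aromatic ring. No measured step touches the aryl group on that nitrogen, and the only step shown is unreadable, so nothing bears directly on this change. Because every measurement sits at the limit of > 25000 nM in this assay, at which 3 of the 3 values shown sit, nothing suggests that this exchange would move the value into the readable range. Compound 4 is therefore expected to give 35000 nM in this assay, within 12000 nM to 100000 nM, most likely reported again as a limit. The expected step that the limit leaves unreadable from compound 1 to compound 4 is estimated as none beyond the scatter.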

Compound 4, half-maximal inhibitory concentration: > 25000 nM
Compound 4 gave a limit, no number (the forecaster's own chance of this, stated with the estimate: 80%); the middle value is on the limit's open side.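

In this assay compound 4 gives > 25000 nM, a limit of the assay and not a number. No step from compound 1 to compound 4 can be read, because both sit at the same limit: the limit of > 25000 nM in this assay, at which 4 of the 4 values shown sit.

The compounds shown leave open whether any change to the shared core gives a readable value in this assay.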